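Ortho tert-butyl in place of ethyl on the shared core

The source may report more compounds than this note shows. Statements on the series, on what has been measured and on what is new or still open speak of the compounds shown alone.

Measured compounds:
compound 1 `CCc1ccc(NC(N)=S)cc1` — 88%
compound 2 `COc1ccc(NC(N)=S)cc1` — 80%
compound 3 `CCc1ccccc1NC(N)=S` — < 10%

Of the compounds shown here, three share one core and have been tested in a functional assay on B16 cells (Mus musculus) for inhibition, tested at 10 uM; a higher number here means more inhibition at the concentration tested (going by the name of the read-out), a lower number less inhibition. Compound 1 `CCc1ccc(NC(N)=S)cc1` gives 88% in this assay, and compound 2 `COc1ccc(NC(N)=S)cc1` gives 80%. Going by the values given here, the only measured step between them, a number 8 percentage points lower from compound 1 to compound 2 (within the scatter), is a methoxy in place of ethyl on an aromatic carbon. Compound 3 `CCc1ccccc1NC(N)=S` stands apart from these two: its value in this assay, < 10%, is a limit of the assay and not a number (the limit of < 10% in this assay, at which 1 of the 3 values shown sits).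

Compound 4 `CC(C)(C)c1ccccc1NC(N)=S` has not yet been measured. It differs from compound 3 by tert-butyl in place of ethyl on an aromatic carbon. Among the compounds with values here, no measured step touches this change: the step from compound 1 to compound 2 concerns a different group at a different place on the ring, and it was within the scatter in any case. Starting from a compound that sits at the limit, compound 4 is expected to remain near that limit, with an expected step that the limit leaves unreadable from compound 3 to compound 4. The estimate for compound 4 in this assay is 8%, in a range from 0% to 22%.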

Compound 4, a percentage reported as inhibition, at one concentration (the size of the read-out at that concentration, not a potency): < 10%
Compound 4: a limit, no number; the forecaster's own chance of this, stated with the estimate: 65%; the middle value does not contradict the limit.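

Compound 3 and compound 4 both sit at a limit of this assay and not at a number, so no step can be read between them: the limit of < 10% in this assay, at which 2 of the 4 values shown sit.

The compounds shown leave open whether tert-butyl and ethyl in this place differ at all in this assay.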